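The source may report more compounds than this note shows. Statements on the series, on what has been measured and on what is new or still open speak of the compounds shown alone.

Compound 1 `COc1ccc(Nc2ncccc2C(=O)NNS(=O)(=O)c2ccc(C)cc2)cc1`: 84%
Compound 2 `O=C(NNS(=O)(=O)c1ccc(F)cc1)c1cccnc1Nc1ccc(Cl)cc1Cl`: 0%

Of the compounds shown here, two have so far been measured in a functional assay on NCI-H460 cells (Homo sapiens) for inhibition, tested at 10 uM; a higher number here means more inhibition at the concentration tested (going by the name of the read-out), a lower number less inhibition. In this assay compound 1 gives 84%, while compound 2 gives 0%. Compound 2 therefore stands lowest of the two numbers; its nearest neighbour is compound 1, whose reading lies far above that of compound 2, well beyond the scatter of repeated measurements. Going by the values given here, no two measured compounds differ in a single place, so no measured step can be drawn on to judge the change that follows.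

Compound 3 `O=C(NNS(=O)(=O)c1ccc(F)cc1)c1cccnc1Nc1ccc(F)cc1` has not yet been measured. It differs from compound 2 in one place: 4-fluorophenyl in place of 2,4-dichlorophenyl on a nitrogen on an aromatic ring. The rest of the molecule stays as in compound 2.

Because compound 2 gives 0%, the read-out of compound 3 cannot fall below it, and any step from compound 2 would be upward or flat. Without a measured step of this kind, the size is uncertain. The expected step is a number 25 percentage points higher from compound 2 to compound 3 (beyond the scatter), a moderate rise that might also stay within the scatter. Compound 3 is expected to give about 25%, within a range from 0% to 70%.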

Compound 3, a percentage reported as inhibition, at one concentration (the size of the read-out at that concentration, not a potency): 62%
Beside the measured number, compound 3's estimate is 37 percentage points below it; the measured number falls inside the stated range.
By their numbers in this assay, from the lowest: compound 2; then compound 3; then compound 1.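

Going by these compounds alone, on the nitrogen on an aromatic ring, the exchange of 2,4-dichlorophenyl for 4-fluorophenyl is the first single change that can be read in this assay, and it appears as a number 62 percentage points higher from compound 2 to compound 3 (beyond the scatter). With the rest of the molecule held as in compound 2, the aryl group on this nitrogen alone separates the lower number of compound 2 from the higher number of compound 3 at the concentration tested. No measurement shown here accounts for the size of this step, and the reason for it remains unknown.

The change removes two chlorine atoms and brings in one fluorine atom in a single step, so the compounds shown do not tell whether the rise follows the loss of the chlorines, the arrival of the fluorine or both, a question that a plain phenyl group or a phenyl group with a single chlorine on the same nitrogen would help to settle. Also open, going by these compounds, is how an amine or a carboxylic acid on this aryl ring would read, and whether the step would hold with the other parts of the molecule changed, since compound 1 differs from compound 3 in more than one place.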